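Moving the Fluorine on Compound 2

The source may hold more compounds than are shown below. What is called first, only, known or untested is meant among the compounds shown, and "the series" means these compounds.

In an ADME assay on MT4 cells (Homo sapiens) for cytotoxicity, read by MTT assay, with a stated time of 96 h (a lower number here means that less compound is tolerated, a higher number that more compound is tolerated), compound 1 `NS(=O)(=O)c1ccc(N2N=C(c3ccccc3)CC2c2ccccc2Cl)cc1` gives 44000 nM and compound 2 `NS(=O)(=O)c1ccc(N2N=C(c3ccc(Oc4ccccc4)cc3)CC2c2cccc(F)c2)cc1` gives 25000 nM, two numbers that lie within the usual scatter of each other. Compound 3 `NS(=O)(=O)c1ccc(N2N=C(c3ccc(Oc4ccccc4)cc3)CC2c2ccc(F)cc2)cc1` has not yet been measured. It carries 4-fluorophenyl in place of 3-fluorophenyl on a saturated ring carbon. Going by the values given here, no measured pair shows what a change of this kind does, so no step beyond the scatter is expected in this assay. The expected step runs a 1.0-fold higher number from compound 2 to compound 3 (0.02 log units; within the scatter). For compound 3 the estimated value is 26000 nM, with an expected range from 12000 nM to 55000 nM.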

Compound 3, half-maximal cytotoxic concentration: 33000 nM
For compound 3 the middle estimate is 1.3-fold (0.10 log units) below the measured one; the range from low to high includes it.
By their numbers in this assay, from the lowest: compounds 2, 3 and 1 (each within the scatter of the next).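

Swapping 3-fluorophenyl for 4-fluorophenyl on this saturated ring carbon gives, in this assay, a small step (a 1.3-fold higher number from compound 2 to compound 3 (0.12 log units; within the scatter)). Going by these compounds alone, this is the one pair here that differs in a single place, and it shows that compound 2 and compound 3 cannot be told apart in this assay, so the place of the fluorine on this phenyl ring makes no readable difference between these two positions. Nothing measured here offers an explanation for this result. Still open, going by these compounds, is whether an amine or a carboxylic acid in place of the fluorine would stay within the scatter.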